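The source may hold more compounds than are shown below. What is called first, only, known or untested is meant among the compounds shown, and "the series" means these compounds.

Measured so far in an ADME assay on a cell-free system (plasma, Rattus norvegicus, strain Sprague-Dawley) for metabolic stability, with a stated time of 30 min, tested at 50 mg/mL; on this read-out lower numbers stand for a less stable compound and higher numbers for a more stable compound: compound 1 `CCCc1nc(C(C)(C)O)c(C(=O)NCCNCCO)n1Cc1ccc(-c2ccccc2C2=NNNN2)cc1`, which gives 98.9%; compound 2 `CCCc1nc(C(C)(C)O)c(C(=O)OCc2c[nH]c(=O)[nH]c2=O)n1Cc1ccc(-c2ccccc2C2=NNNN2)cc1`, which gives 96.3%.

Within the data shown here, compound 2 sits beside compound 1, the only other compound measured, the two separated by a number 2.6 percentage points lower from compound 1 to compound 2 (within the scatter). Compound 3 `CCCc1nc(C(C)(C)O)c(C(=O)OCCCCCC[N+](=O)[O-])n1Cc1ccc(-c2ccccc2C2=NNNN2)cc1` differs from compound 2 by a group of 8 heavy atoms (5 carbon, 1 nitrogen, 2 oxygen; no ring) in place of a group of 8 heavy atoms (4 carbon, 2 nitrogen, 2 oxygen; one six-membered aromatic ring with 2 hetero atoms), on a saturated chain carbon bound to an oxygen next to a carbonyl group. Among the measured compounds shown here, the one measured step that bears on this exchange, at the carbonyl, stayed within the scatter, so no shift beyond the scatter is expected here either. In this assay compound 3 is therefore expected to give about 94%, with a likely range from 80% to 100%. The expected step is a number 2.3 percentage points lower from compound 2 to compound 3 (within the scatter), nothing beyond the scatter.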

Compound 3, percent of the compound remaining: 100%
Estimate against measurement, compound 3: 6 percentage points below; measured number inside the range.
By their numbers in this assay, from the lowest: compounds 2, 1 and 3 (each within the scatter of the next).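

Putting 5-nitropentyl in place of the group with the six-membered aromatic ring, on a saturated chain carbon bound to an oxygen next to a carbonyl group, gives in this assay a number 3.7 percentage points higher from compound 2 to compound 3 (within the scatter). Putting (6-nitrohexyl)oxy in place of (2-((2-hydroxyethyl)amino)ethyl)amino on a carbonyl carbon gives a number 1.1 percentage points higher from compound 1 to compound 3 (within the scatter), so at this position a chain with no ring and a nitro end reads the same as both earlier groups. No available evidence bears on this result. As far as these compounds go, whether a carboxylic acid or a primary amine at the end of the chain would move the number beyond the scatter remains open.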